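Anilide variation on a shared piperazine-acetamide series

The source may report more compounds than this note shows. Statements on the series, on what has been measured and on what is new or still open speak of the compounds shown alone.

Measured so far:
compound 1 `O=C(CN1CCN(c2nnc(Cc3ccncc3)c3ccccc23)CC1)Nc1ccc(F)c(Cl)c1` — 12300 nM
compound 2 `Cc1ccc(F)cc1NC(=O)CN1CCN(c2nnc(Cc3ccccc3)c3ccccc23)CC1` — "not active" (no number reported)
compound 3 `Cc1ccc(NC(=O)CN2CCN(c3nnc(Cc4ccccc4)c4ccccc34)CC2)c(C)c1` — "not active" (no number reported)

In a functional assay on A549 cells (Homo sapiens) for cytotoxicity, read by MTT assay, with a stated time of 72 h (on this read-out lower numbers stand for stronger inhibition and higher numbers for weaker inhibition), compound 1 gives 12300 nM, a weak result. Compound 2 is recorded in this assay as "not active" (no number reported), without a number. Compound 3 likewise stands in this assay as "not active" (no number reported); no number is reported for it, and the same holds for compound 2, so compound 3 cannot be ranked on the figures shown.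

Compound 4 `O=C(CN1CCN(c2nnc(Cc3ccccc3)c3ccccc23)CC1)Nc1ccc(F)c(Cl)c1` follows from compound 3 by 3-chloro-4-fluorophenyl in place of 2,4-dimethylphenyl on an amide-type nitrogen. For the measured compounds named here, no measured step exists for this change. Compound 1 carries the same anilide and gives 12300 nM in this assay, so weak inhibition is the most likely outcome for compound 4, with a real chance of no number at all. Compound 4 is expected at about 20000 nM, within 6000 nM to 80000 nM.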

Compound 4, half-maximal inhibitory concentration: "not active" (no number reported)
For compound 4 the study gives words and no number, so the estimate cannot be set against anything.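

Compound 3 and compound 4 both stand as "not active" with no number, so no step can be read between them. No supporting evidence bears on this result. In this assay the compounds shown leave open how far the anilide alone shifts the read-out.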